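Changing the Aromatic Group on the Shared Core

A few compounds are considered here, and "the series" means these few. Any claim that something is new, unique, unknown or untested is made for them only; others in the source may bear on it.

Compound 1 `CN(C)C(=O)c1cccnc1NCCCN1CCN(c2ccccc2C#N)CC1`: 2 nM
Compound 2 `CCCc1ccccc1N1CCN(CCCNc2ncccc2C(=O)N(C)C)CC1`: 0.2 nM
Compound 3 `CN(C)C(=O)c1cccnc1NCCCN1CCN(c2ccccc2C2CC2)CC1`: 0.631 nM

These numbers come from a functional assay for antagonist activity at Alpha-1A adrenergic receptor (Oryctolagus cuniculus); on this read-out higher numbers stand for weaker binding and lower numbers for tighter binding. Compound 3 stands second highest of the three: compound 2 sits below it and compound 1 above it, each gap beyond the scatter. Compound 4 `COc1cc(C)ccc1N1CCN(CCCNc2ncccc2C(=O)N(C)C)CC1` differs from compound 3 by 2-methoxy-4-methylphenyl in place of 2-cyclopropylphenyl on an amine nitrogen in a ring. Within the data shown here, no measured step matches this exact change. The three known steps each swap one group on an aromatic carbon: a 10-fold lower number from compound 1 to compound 2 (1.00 log units; beyond the scatter), a 3.2-fold lower number from compound 1 to compound 3 (0.50 log units; beyond the scatter) and a 3.2-fold higher number from compound 2 to compound 3 (0.50 log units; beyond the scatter), all modest. The new group again alters a substituent on that ring, so the step of a 1.6-fold higher number from compound 3 to compound 4 (0.20 log units; within the scatter) is expected to be small, its direction uncertain. Compound 4 is therefore estimated at 1 nM, within a range from 0.25 nM to 4 nM.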

Compound 4, dissociation constant: 0.794 nM
Estimate against measurement, compound 4: 1.3-fold (0.10 log units) above; low and high end bracket the measured number.
By their numbers in this assay, from the lowest: compound 2; then compounds 3 and 4 (each within the scatter of the next); then compound 1.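

Replacing 2-cyclopropylphenyl with 2-methoxy-4-methylphenyl on the ring amine nitrogen adds an oxygen and a hydrogen-bond acceptor and removes the three-membered ring, yet this assay records a 1.3-fold higher number from compound 3 to compound 4 (0.10 log units; within the scatter) and so no clear change. The new group still stands apart from the others: a 4.0-fold higher number from compound 2 to compound 4 (0.60 log units; beyond the scatter) separates it from 2-propylphenyl, while a 2.5-fold lower number from compound 1 to compound 4 (0.40 log units; beyond the scatter) separates it from 2-cyanophenyl. No available evidence explains these results.

The compounds shown leave open whether the methoxy or the methyl group matters more here, and how an amine or a carboxylic acid on this aromatic ring would behave.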